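Working notes: from pentyl to phenyl

This account rests on a few compounds, and the source may have more. Where it says the series, first, only, none or still open, it means among the compounds named here.

- compound 1 `CC/C=C\C[C@H]1C(=O)C=C[C@H]1CC(=O)OCC`: 20000 nM
- compound 2 `CC/C=C\C[C@H]1C(=O)C=C[C@H]1CC(=O)OCCCCC`: 25000 nM

In a functional assay on RAW264.7 cells (Mus musculus) for inhibition, read by ELISA, with a stated time of 24 h (on this read-out higher numbers stand for an effect only at larger amounts of compound and lower numbers for an effect already at smaller amounts), compound 2, at 25000 nM, stands level with compound 1 within the scatter. Compound 3 `CC/C=C\C[C@H]1C(=O)C=C[C@H]1CC(=O)Oc1ccccc1` differs from it by phenyl in place of pentyl on an oxygen next to a carbonyl group. Within the data shown here, the only measured step, a 1.3-fold higher number from compound 1 to compound 2 (0.10 log units; within the scatter), lies within the scatter and brings in no ring, so it bears on this change only loosely. No step beyond the scatter is expected in this assay, in either direction. The estimated step is a 1.4-fold lower number from compound 2 to compound 3 (0.14 log units; within the scatter). For compound 3 the estimate is 18000 nM, with an expected range of 8000 nM to 40000 nM.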

Compound 3, half-maximal effective concentration: 33000 nM
Estimate against measurement, compound 3: 1.8-fold (0.26 log units) below; the measured number falls inside the stated range.
By their numbers in this assay, from the lowest: compounds 1, 2 and 3 (each within the scatter of the next).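

In this assay, phenyl in place of pentyl on an oxygen next to a carbonyl group gives a 1.3-fold higher number from compound 2 to compound 3 (0.12 log units; within the scatter) and phenyl in place of ethyl gives a 1.7-fold higher number from compound 1 to compound 3 (0.22 log units; within the scatter) and neither step leaves the scatter. This position therefore carries a six-membered aromatic ring of carbon only as well as a chain, with no separation among compound 1, compound 2 and compound 3. Nothing available explains why the numbers stay level.

Open, on these data alone, is whether an amine, a carboxylic acid or a chlorophenyl group at this place would move the number beyond the scatter.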